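The compounds below may be only part of what the source reports. "The series", "measured", "known", "first", "only" and "open" are said of these compounds alone.

The antiproliferative activity of these compounds was tested in a functional assay on SW-620 cells (Homo sapiens) for antiproliferative activity, read by MTT assay, with a stated time of 24 h; on this read-out lower numbers stand for stronger inhibition and higher numbers for weaker inhibition. Compound 1, `COc1ccc(C(=O)/C=C/c2cccc([N+](=O)[O-])c2)c2c1C=CC(C)(C)O2`, is the only one of the three measured compounds to give a definite number: in this assay compound 1 gives 4090 nM. The other two came back only as limits. Compound 2, `COc1ccc(C(=O)/C=C/c2cccc3ccccc23)c2c1C=CC(C)(C)O2`, is reported in this assay as > 10000 nM, a limit of the assay rather than a measured value. Compound 3, `CCOc1cc(/C=C/C(=O)c2ccc(OC)c3c2OC(C)(C)C=C3)ccc1O`, likewise stops in this assay at > 10000 nM, again a limit. For the measured compounds named here, the picture is therefore shaped by the limit of > 10000 nM in this assay, at which 2 of the 3 values shown sit, and compound 1 stands as the single compound with a measured inhibitory concentration. Going by the values given here, since no two measured compounds differ in only one place, no step can be read from these results.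

Compound 4, `COc1ccc(C(=O)/C=C/c2cc(Cl)ccc2O)c2c1C=CC(C)(C)O2`, shares the core of compound 1 and differs from it in one place: 5-chloro-2-hydroxyphenyl in place of 3-nitrophenyl on a double-bonded chain carbon bound to a double-bonded chain carbon. Among the compounds with values here, no measured step shows how large an effect such an exchange has. Within the data shown here, with compound 1 at 4090 nM as the only definite number, the outlook is cautious. The step of a 1.5-fold higher number from compound 1 to compound 4 (0.17 log units; within the scatter) is expected to be modest, toward weaker inhibition, and not clearly beyond the usual scatter. Compound 4 is estimated to give 6000 nM, with a likely range from 2000 nM to 20000 nM.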

Compound 4, half-maximal inhibitory concentration: 4230 nM
Estimate against measurement, compound 4: 1.4-fold (0.15 log units) above; low and high end bracket the measured number.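

For the compounds shown here, this is the first step that can be read at this place, and in this assay it comes to a 1.0-fold higher number from compound 1 to compound 4 (0.01 log units; within the scatter). It shows that 5-chloro-2-hydroxyphenyl can stand in place of 3-nitrophenyl on a double-bonded chain carbon bound to a double-bonded chain carbon without the read-out leaving the usual scatter, even though the two groups share little beyond their six-membered aromatic ring of carbon: the entering group brings a chlorine and a hydrogen-bond donor, while the leaving group holds a nitrogen and has no such donor. This exchange of quite different groups therefore gives two numbers that cannot be told apart, although a single pair sets no rule for other groups at this place.

Going by these compounds, whether an unsubstituted phenyl, or a ring bearing an amine or a carboxylic acid, would give a similar number here stays open, as does what the chlorine and the hydroxy group each contribute on their own. The remaining compounds offer little to compare against: the limit of > 10000 nM in this assay, at which 2 of the 4 values shown sit.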